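The compounds below may be only part of what the source reports. "The series", "measured", "known", "first", "only" and "open" are said of these compounds alone.

Three compounds that share one core and differ only in the group attached to the oxygen next to the carbonyl at the end of the chain have been measured in an ADME assay (liver) for pharmacokinetics, with Liver microsome (Rattus norvegicus) as the target, using microsomes; on this read-out lower numbers stand for a shorter-lived compound and higher numbers for a longer-lived compound. Compound 1 `CCOc1cc(NC(=O)C2(NC(=O)c3ccc4c(C5CCCC5)c(-c5ncc(Cl)cn5)n(C)c4c3)CCC2)ccc1/C=C/C(=O)OC(=O)C[C@H](O)C(=O)O` gives 7.92 h, compound 2 `CCOc1cc(NC(=O)C2(NC(=O)c3ccc4c(C5CCCC5)c(-c5ncc(Cl)cn5)n(C)c4c3)CCC2)ccc1/C=C/C(=O)OCC(Cl)(Cl)Cl` gives 0.233 h, and compound 3 `CCOc1cc(NC(=O)C2(NC(=O)c3ccc4c(C5CCCC5)c(-c5ncc(Cl)cn5)n(C)c4c3)CCC2)ccc1/C=C/C(=O)OCc1ccccc1` gives 2.17 h. Compound 3 therefore stands second highest of the three, between the two others: the step of a 3.6-fold lower number from compound 1 to compound 3 (0.56 log units; beyond the scatter) and the step of a 9.3-fold higher number from compound 2 to compound 3 (0.97 log units; beyond the scatter) show that the ester portion alone moves this read-out by a wide margin. Compound 4 `CCOc1cc(NC(=O)C2(NC(=O)c3ccc4c(C5CCCC5)c(-c5ncc(Cl)cn5)n(C)c4c3)CCC2)ccc1/C=C/C(=O)OCC(=O)OC` carries the change (methoxycarbonyl in place of phenyl on a saturated chain carbon bound to an oxygen next to a carbonyl group). Within the data shown here, no measured step swaps exactly these two groups, but the step of a 9.3-fold higher number from compound 2 to compound 3 (0.97 log units; beyond the scatter) shows that replacing one small substituent on that carbon by another can shift the number strongly in either direction. Compound 4 is expected to fall below compound 3 by a 2.7-fold lower number from compound 3 to compound 4 (0.43 log units; beyond the scatter), giving an estimated 0.8 h, with a likely range from 0.2 h to 3 h.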

Compound 4, half-life: 2.08 h
Beside the measured number, compound 4's estimate is 2.6-fold (0.41 log units) below it; low and high end bracket the measured number.
By their numbers in this assay, from the lowest: compound 2; then compounds 4 and 3 (each within the scatter of the next); then compound 1.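

In this assay, methoxycarbonyl and phenyl on this saturated chain carbon cannot be told apart, with a 1.0-fold lower number from compound 3 to compound 4 (0.02 log units; within the scatter), even though one is a ring of carbon only and the other has no ring and carries two hydrogen-bond acceptors. Trichloromethyl at the same carbon now differs from both groups, with an 8.9-fold higher number from compound 2 to compound 4 (0.95 log units; beyond the scatter) and the earlier 9.3-fold higher number from compound 2 to compound 3 (0.97 log units; beyond the scatter), while the group in compound 1 also stands apart, with a 3.8-fold lower number from compound 1 to compound 4 (0.58 log units; beyond the scatter). No evidence is available to explain these differences.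

On these data alone, whether other groups on this carbon, such as an amine or a longer chain, would match phenyl and methoxycarbonyl or move the half-life remains open. Also open, as far as these compounds go, is which part of the (2-carboxy-2-hydroxyethyl)carbonyl group in compound 1 goes with its higher number.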